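The source may hold more compounds than are shown below. What is called first, only, known or untested is meant among the compounds shown, and "the series" means these compounds.

In a functional assay on A2780 cells (Homo sapiens) for antiproliferative activity, read by MTT assay, with a stated time of 48 h (on this read-out lower numbers stand for stronger inhibition and higher numbers for weaker inhibition), compound 1 `COc1ccc(C(=O)c2cc(OC)c(OC)c(OC)c2)c(NC(=O)CO)c1` gives 100 nM and compound 2 `COc1ccc(C(=O)c2cc(OC)c(OC)c(OC)c2)c(NC(=O)CN(C)C)c1` gives 580 nM as the higher of the two numbers, the weaker result so far. Compound 3 `COc1ccc(C(=O)c2cc(OC)c(OC)c(OC)c2)c(NC(=O)CN)c1` differs from compound 2 by amino in place of dimethylamino on a saturated chain carbon bound to a carbonyl carbon in one place, with amino in place of dimethylamino on a saturated chain carbon bound to a carbonyl carbon. Going by a 5.8-fold higher number from compound 1 to compound 2 (0.76 log units; beyond the scatter) as the one measured step at this place, a modest drop in this assay is expected, though that single step is thin support. The expected move is a 2.9-fold lower number from compound 2 to compound 3 (0.46 log units; beyond the scatter) on this reasoning. Compound 3 is estimated at 200 nM within a range of 60 nM to 700 nM for now.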

Compound 3, half-maximal inhibitory concentration: 190 nM
For compound 3 the middle estimate is 1.1-fold (0.02 log units) above the measured one; measured number inside the range.
By their numbers in this assay, from the lowest: compounds 1 and 3 (each within the scatter of the next); then compound 2.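

In this assay, amino in place of dimethylamino gives a 3.1-fold lower number from compound 2 to compound 3 (0.48 log units; beyond the scatter), so the weaker result with dimethylamino does not extend to every nitrogen group on this saturated chain carbon bound to a carbonyl carbon. Amino in place of hydroxy gives a 1.9-fold higher number from compound 1 to compound 3 (0.28 log units; within the scatter), leaving these two groups unseparated at this place. Nothing on hand explains the difference between dimethylamino and amino.

Still open, as far as these compounds go, is whether methylamino stays with compound 1 and compound 3 or falls with compound 2. From the compounds shown here alone, the results for a carboxylic acid or a longer chain carrying the amino group at this place also remain open.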